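The source may report more compounds than this note shows. Statements on the series, on what has been measured and on what is new or still open speak of the compounds shown alone.

In a functional assay on the whole organism (strain Swiss albino) with Mus musculus as the target, with stated times of 30 min and 10 min, at a dose of 50 mg/kg by the oral route (a lower number here means less inhibition, a higher number more inhibition at the dose given (going by the name of the read-out)), compound 1, `CC(=O)c1c(NNc2ccc(Cl)cc2)cc(C)oc1=O`, gives 75.1%. Compound 2, `CC(=O)c1c(NNc2ccc(Br)cc2)cc(C)oc1=O`, gives 53.1%, and the change between them is bromo in place of chloro on an aromatic carbon; that change made a step of a number 22 percentage points lower from compound 1 to compound 2 (beyond the scatter). Compound 3, `Cc1cc2nn(-c3ccc(Cl)cc3)c(C)c2c(=O)o1`, is built on a different core, and how its core differs from that of compound 1 is not broken down here. In this assay compound 3 gives 65.3%, which lies second of the three numbers. Compound 4, `Cc1cc2nn(-c3ccc(Br)cc3)c(C)c2c(=O)o1`, has not yet been measured; it differs from compound 3 by bromo in place of chloro on an aromatic carbon, the same change that separates compound 1 from compound 2, at the same kind of place. That change appears twice among these compounds, and it is measured only once. Because of the step of a number 22 percentage points lower from compound 1 to compound 2 (beyond the scatter), compound 4 is expected to sit lower than compound 3, and the step expected from compound 3 to compound 4 is a number 17.3 percentage points lower from compound 3 to compound 4 (beyond the scatter). Compound 4 is therefore estimated at 48%, with a range from 30% to 66% that allows for a smaller step on this core.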

Compound 4, a percentage reported as inhibition, in the whole organism at one dose (the size of the read-out at that dose, not a potency): 44.9%
Compound 4: middle estimate off by 3.1 percentage points, on the high side; the range from low to high includes it.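

In this assay, bromo in place of chloro on an aromatic carbon, para to a large group, gave a step of a number 20.4 percentage points lower from compound 3 to compound 4 (beyond the scatter). The change therefore carried over from the core of compound 1 to the core of compound 3 with a step of much the same size: the same change on two cores in this assay, a number 22 percentage points lower (beyond the scatter) from compound 1 to compound 2 and a number 20.4 percentage points lower (beyond the scatter) from compound 3 to compound 4, 1.6 percentage points apart, within the scatter of two such steps This agreement rests on just two pairs, with the change in the same kind of place and at a single dose, so it shows neither that the step would hold on any further core nor why bromo gives the lower number.

The compounds shown leave open how a fluoro group, a methoxy group or an amine in that place on the six-membered aromatic ring would read in this assay, as only chloro and bromo appear there. They also leave open whether a step of this size would recur at another place on the aromatic ring, or at another dose.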